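Fluorophenyl shift on the sulfonamide nitrogen

A few compounds are considered here, and "the series" means these few. Any claim that something is new, unique, unknown or untested is made for them only; others in the source may bear on it.

Measured in a physicochemical assay for lipophilicity, at pH 7.4; a lower number here means a more polar compound, a higher number a more lipophilic compound
- compound 1 `CC(C)CN(c1ccccc1F)S(=O)(=O)c1ccc2c(c1)C(O)CC(C1CCOCC1)O2` gives 3.39
- compound 2 `CCc1ccc(N(CC(C)C)S(=O)(=O)c2ccc3c(c2)C(C)CC(C2CCOCC2)O3)cc1` gives 5.71
- compound 3 `CCc1ccc(N(CC(C)C)S(=O)(=O)c2ccc3c(c2)C(O)CC(C2CCN(C(=O)C4CCCC4)CC2)O3)cc1` gives 5.04

In this assay compound 1 stands lowest of the three, with compound 3 the nearest and compound 2 the furthest, both beyond the scatter. Compound 4 `CC(C)CN(c1cccc(F)c1)S(=O)(=O)c1ccc2c(c1)C(O)CC(C1CCOCC1)O2` differs from compound 1 in one place 3-fluorophenyl in place of 2-fluorophenyl on a sulfonamide nitrogen with 3-fluorophenyl in place of 2-fluorophenyl on a sulfonamide nitrogen. Going by the values given here, no measured pair shows a change of this kind, so the data give no direct guide. No step beyond the scatter is expected in this assay and the estimated step is small a number 0.06 log units higher from compound 1 to compound 4 (within the scatter) for now. Compound 4 is expected at 3.45 with an estimated range from 3.05 to 3.85 until it is measured.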

Compound 4, distribution coefficient: 3.39
Estimate against measurement, compound 4: 0.06 log units above; the range from low to high includes it.
By their numbers in this assay, from the lowest: compounds 1 and 4 (each within the scatter of the next); then compound 3; then compound 2.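

Exchanging 2-fluorophenyl for 3-fluorophenyl on a sulfonamide nitrogen, the only one-place pair shown in the series, gives in this assay a reading of no change at the digits printed from compound 1 to compound 4 (within the scatter). With the rest of compound 1 held constant, this assay does not separate these two fluorophenyl groups at this place. Nothing available explains this result. Still open, from the compounds shown here alone, is whether an amine or a carboxylic acid at this place, in place of the fluorine-bearing phenyl, would shift the number. Also open, going by these compounds, is whether the same exchange reads alike with the rest of the molecule changed, as in compound 3.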